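Aryl substituent variation on the shared core: compound 4

A few compounds are considered here, and "the series" means these few. Any claim that something is new, unique, unknown or untested is made for them only; others in the source may bear on it.

Measured compounds:
compound 1 `CCCS(=O)(=O)Nc1ccc(F)c(C(=O)c2n[nH]c3ncc(-c4ccccc4OC)cc23)c1F` — in an assay for binding affinity to dual specificity mitogen-activated protein kinase kinase 4 (Homo sapiens), read by KINOMEscan, tested at 100 nM (a higher number here means a weaker effect of the compound at the concentration tested, a lower number a stronger effect), compound 1 gives 1.9%
compound 2 `CCCS(=O)(=O)Nc1ccc(F)c(C(=O)c2n[nH]c3ncc(-c4ccc(N(C)C)cc4)cc23)c1F` — in this assay compound 2 gives 2.5%
compound 3 `CCCS(=O)(=O)Nc1ccc(F)c(C(=O)c2n[nH]c3ncc(-c4ccc(NS(C)(=O)=O)cc4)cc23)c1F` — in this assay compound 3 gives 0.85%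

The three measured compounds share one core and differ only in the aryl group attached to it. On the numbers, compound 3 sits at the low end, but the gaps to the other two, a number 1.1 percentage points lower from compound 1 to compound 3 (within the scatter) and a number 1.7 percentage points lower from compound 2 to compound 3 (within the scatter), are both within the scatter, so the three are not separated by this read-out. The same holds for a number 0.6 percentage points higher from compound 1 to compound 2 (within the scatter).

Compound 4 `CCCS(=O)(=O)Nc1ccc(F)c(C(=O)c2n[nH]c3ncc(-c4ccc(C(N)=O)cc4)cc23)c1F` is the next member. Its structural change from compound 3 is carbamoyl in place of methanesulfonamido on an aromatic carbon.

Among the measured compounds shown here, no measured step exchanges the methanesulfonamido group for a carbamoyl group. The nearest information is the set of steps among compounds 1, 2 and 3, which swap one aryl substituent for another without any change beyond the scatter. By analogy, the change to compound 4 is expected to give no step beyond the scatter either, so the estimated step is a number 0.7 percentage points higher from compound 3 to compound 4 (within the scatter).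

Compound 4 is therefore estimated at 1.5% in this assay, with a range from 0.4% to 5%.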

Compound 4, a percentage reported as activity, at one concentration (the size of the read-out at that concentration, not a potency): 0.15%
Estimate against measurement, compound 4: 1.4 percentage points above; measured number below the stated range.
By their numbers in this assay, from the lowest: compounds 4, 3, 1 and 2 (each within the scatter of the next).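

Carbamoyl, with 3 heavy atoms against 5 for methanesulfonamido, can stand on the aromatic carbon para to a large group without separating compound 4 from compound 3 in this assay, with a number 0.7 percentage points lower from compound 3 to compound 4 (within the scatter) as the step. The two other comparisons give the same reading, with a number 2.4 percentage points lower from compound 2 to compound 4 (within the scatter) and a number 1.8 percentage points lower from compound 1 to compound 4 (within the scatter) as their steps, so a primary amide now joins methanesulfonamido, dimethylamino and the 2-methoxyphenyl variant among the aryl groups that this read-out does not separate. Nothing available bears on the reason for this result.

At a single concentration, with all four compounds within the scatter of the next, the series gives no order among these aryl groups and does not show whether any group at this place would produce a step beyond the scatter. A carboxylic acid, an aminomethyl group or a plain phenyl ring at this place would test how far that insensitivity extends, and measurements at further concentrations would be needed to tell compound 4 from compound 3 at all.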